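Trading a formyl for a vinyl on the silicon-bound ring

The source may hold more compounds than are shown below. What is called first, only, known or untested is meant among the compounds shown, and "the series" means these compounds.

Compound 1 `CCN(C/C=C/C#CC(C)(C)C)Cc1cccc(OC[Si](C)(C)c2cccc(C)c2)c1` gives 3000 nM in a functional assay on liver (Sus scrofa) for inhibition of squalene monooxygenase (Homo sapiens), using microsomes (a lower number here means a stronger inhibitor, a higher number a weaker inhibitor), compound 2 `CCN(C/C=C/C#CC(C)(C)C)Cc1cccc(OC[Si](C)(C)c2ccccc2C)c1` gives 30 nM, and compound 3 `CCN(C/C=C/C#CC(C)(C)C)Cc1cccc(OC[Si](C)(C)c2ccc(C=O)cc2)c1` gives 100 nM. Compound 3 thus holds the second highest of the three numbers; the step of a 3.3-fold higher number from compound 2 to compound 3 (0.52 log units; beyond the scatter) is modest, while the steps of a 100-fold lower number from compound 1 to compound 2 (2.00 log units; beyond the scatter) and a 30-fold lower number from compound 1 to compound 3 (1.48 log units; beyond the scatter) are large. All three measured steps alter the substituent on the phenyl ring carried by the silicon, so each bears on the change to compound 4 `C=Cc1ccc([Si](C)(C)COc2cccc(CN(CC)C/C=C/C#CC(C)(C)C)c2)cc1`, which differs from compound 3 by vinyl in place of formyl on an aromatic carbon. The change keeps the substituent para to a large group and only exchanges formyl for vinyl, which resembles the modest step seen between compound 2 and compound 3 more than the large steps from compound 1. The expectation is therefore a step of a 1.7-fold lower number from compound 3 to compound 4 (0.22 log units; within the scatter) in this assay, of modest size and of uncertain direction. Compound 4 is estimated at 60 nM, expected to fall between 15 nM and 300 nM.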

Compound 4, half-maximal inhibitory concentration: 70 nM
The estimate for compound 4 lay 1.2-fold (0.07 log units) below the measured number, within the range that was stated.
By their numbers in this assay, from the lowest: compound 2; then compounds 4 and 3 (each within the scatter of the next); then compound 1.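

In this assay, vinyl in place of formyl gives a 1.4-fold lower number from compound 3 to compound 4 (0.15 log units; within the scatter), so at this carbon the oxygen and the hydrogen-bond acceptor of the formyl can be exchanged for an all-carbon group with no step beyond the scatter. The 4-vinylphenyl group also stays close to the 2-methylphenyl group, with a 2.3-fold higher number from compound 2 to compound 4 (0.37 log units; beyond the scatter), and far from the 3-methylphenyl group, with a 43-fold lower number from compound 1 to compound 4 (1.63 log units; beyond the scatter), so the two 4-substituted compounds now sit on the same side of both methyl compounds. No measurement is available here that would explain why the exchange leaves the number within the scatter.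

Going by these compounds, it remains open whether a substituent of another kind, such as an amine, a carboxylic acid or a longer alkyl chain, would be tolerated on this carbon. On these data alone, it is equally open whether vinyl or formyl would behave the same way at another place on the ring.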